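Moving a Carboxy Group: Compound 1 to Compound 4

The compounds below may be only part of what the source reports. "The series", "measured", "known", "first", "only" and "open" are said of these compounds alone.

In an ADME assay on a cell-free system (plasma, Rattus norvegicus) for metabolic stability, read by LC-MS, with a stated time of 60 min, tested at 100 uM (on this read-out lower numbers stand for a less stable compound and higher numbers for a more stable compound), compound 1 `Cc1cc(C(=O)O)ccc1OCCCCOc1ccc(C(=O)CC(C)C)c(O)c1C` gives 100%. Compound 2 `Cc1c(OCCCCOCOc2ccc(C(=O)O)cc2)ccc(C(=O)CC2CCCC2)c1O` stands level with it at 100%, and compound 3 `Cc1c(OCCCCOc2ccc(C(=O)O)cc2Cl)ccc(C(=O)CC2CCCC2)c1O` stands higher at 120%. Compound 4 `Cc1ccc(C(=O)O)cc1OCCCCOc1ccc(C(=O)CC(C)C)c(O)c1C` has the same atoms as compound 1, joined differently, with 5-carboxy-2-methylphenyl in place of 4-carboxy-2-methylphenyl on an oxygen on a saturated carbon. Going by the values given here, only one measured step offers any guide, a number 20 percentage points higher from compound 2 to compound 3 (beyond the scatter). Among the compounds with values here, that modest step swaps a different group, and no measured pair shows this exact change, so it gives only a rough size. The expected step is no change at the digits printed from compound 1 to compound 4 (within the scatter), which means no shift beyond the scatter is expected. For compound 4 the estimated value is 100%, with an expected range of 85% to 115%.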

Compound 4, percent of the compound remaining: 96%
Compound 4: the middle estimate sits 4 percentage points above what was measured; the range from low to high includes it.
By their numbers in this assay, from the lowest: compounds 4, 1 and 2 (each within the scatter of the next); then compound 3.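

In this assay, exchanging 4-carboxy-2-methylphenyl for 5-carboxy-2-methylphenyl on an oxygen on a saturated carbon gives a number 4 percentage points lower from compound 1 to compound 4 (within the scatter), so the two arrangements cannot be told apart on this read-out. Going by these compounds alone, this is the first measured pair here with the same atoms joined differently, and it shows that this particular rearrangement leaves the percentage remaining within the usual scatter. Still open, as far as these compounds go, is whether a tetrazole or an amide in place of the carboxy group would keep the number at this level. No measured evidence here explains the result.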